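This account rests on a few compounds, and the source may have more. Where it says the series, first, only, none or still open, it means among the compounds named here.

The study concerns three analogues built on a shared core. Compound 1 `CC(C)n1cnc2c(Nc3ccccc3)nc(NCOCc3ccc(C(=O)Nc4ccccc4N)cc3)nc21` and compound 2 `CCCCn1cnc2c(Nc3ccccc3)nc(NCOCc3ccc(/C=C/C(=O)Nc4ccccc4N)cc3)nc21` have been measured in a functional assay on HCT-116 cells (Homo sapiens) for antiproliferative activity, read by CCK-8 assay, with a stated time of 72 h, tested at 8 uM; a higher number here means a stronger effect of the compound at the concentration tested, a lower number a weaker effect. In this assay compound 1 gives 18.8%, while compound 2 gives 51.9%, the highest of the two numbers shown; its nearest neighbour is compound 1, whose value lies a gap below that is beyond the usual scatter.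

The account now follows the step from compound 2 to compound 3 `CCCCn1cnc2c(Nc3ccccc3)nc(NCOCc3ccc(C(=O)Nc4ccccc4N)cc3)nc21`, which has not yet been measured in this assay. The change is a single one, on an aromatic carbon of a six-membered aromatic ring of carbon only, para to a large group: (2-aminophenyl)carbamoyl in place of 2-((2-aminophenyl)carbamoyl)ethenyl on an aromatic carbon Compound 3 thus carries the same (2-aminophenyl)carbamoyl group that compound 1 carries, though the two differ elsewhere in the core.

Going by the values given here, no measured step between compounds differing in one place is available, so the expectation rests on the two values shown. Because compound 1, which bears the (2-aminophenyl)carbamoyl group, gives 18.8%, compound 3 is expected to sit below compound 2, and the step from compound 2 to compound 3 is estimated as a number 23.9 percentage points lower from compound 2 to compound 3 (beyond the scatter), a fall beyond the scatter. Compound 3 is therefore estimated at 28%, with a likely range from 12% to 48%.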

Compound 3, a percentage reported as inhibition, at one concentration (the size of the read-out at that concentration, not a potency): 74.9%
For compound 3 the middle estimate is 46.9 percentage points below the measured one, outside the stated range (above it).
By their numbers in this assay, from the lowest: compound 1; then compound 2; then compound 3.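

In this assay, with butyl held on the aromatic nitrogen, (2-aminophenyl)carbamoyl in place of 2-((2-aminophenyl)carbamoyl)ethenyl on the aromatic carbon gives a number 23 percentage points higher from compound 2 to compound 3 (beyond the scatter), so at this position the group without the ethenyl link is the better of the two. With (2-aminophenyl)carbamoyl held in place, butyl in place of isopropyl on the aromatic nitrogen gives a number 56.1 percentage points higher from compound 1 to compound 3 (beyond the scatter), the larger of the two steps, which shows that the low reading of compound 1 cannot be laid on the (2-aminophenyl)carbamoyl group alone and that the group on the aromatic nitrogen matters strongly when this group is present. No measured evidence bears on the cause of either step.

Still open, going by these compounds, is whether the gain from butyl over isopropyl also holds with the ethenyl-linked group, and whether a longer chain such as hexyl on the aromatic nitrogen would extend it. On these data alone, it is also open how a hydroxamic acid or a carboxylic acid would compare at the aromatic carbon, and since each reading comes from a single concentration, these steps say nothing about potency.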